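This account rests on a few compounds, and the source may have more. Where it says the series, first, only, none or still open, it means among the compounds named here.

Compound 2 `COC(=O)[C@@]1(C)CCC=C2[C@@H]1CC[C@@H](C)[C@]2(C)Cc1c(C)[nH]c2c(Br)cccc12` has been measured in a functional assay on HeLa cells (Homo sapiens) for inhibition, read by sulforhodamine B assay, with a stated time of 48 h (on this read-out lower numbers stand for stronger inhibition of growth and higher numbers for weaker inhibition of growth), where compound 2 gives 22000 nM. Its nearest neighbour is compound 1 `COC(=O)[C@@]1(C)CCC=C2[C@@H]1CC[C@@H](C)[C@]2(C)Cc1c(C)[nH]c2ccccc12`, which in this assay gives 11000 nM; the step of a 2.0-fold higher number from compound 1 to compound 2 (0.30 log units; within the scatter) lies within the scatter, so the two numbers cannot be told apart. Compound 3 `COC(=O)[C@@]1(C)CCC=C2[C@@H]1CC[C@@H](C)[C@]2(C)Cc1c(C)[nH]c2c(Cl)cccc12` differs from compound 2 by chloro in place of bromo on an aromatic carbon. Among the measured compounds shown here, no measured step exchanges one halogen for another; the one measured step, a 2.0-fold higher number from compound 1 to compound 2 (0.30 log units; within the scatter), stayed small. A step of a 1.4-fold lower number from compound 2 to compound 3 (0.14 log units; within the scatter) is therefore expected, nothing beyond the scatter. Compound 3 is estimated at 16000 nM, within 7000 nM to 40000 nM.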

Compound 3, concentration for 50% growth inhibition: 17000 nM
Compound 3: the middle estimate sits 1.1-fold (0.03 log units) below what was measured; low and high end bracket the measured number.
By their numbers in this assay, from the lowest: compounds 1, 3 and 2 (each within the scatter of the next).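

In this assay, exchanging one halogen for the other on this aromatic carbon gives a 1.3-fold lower number from compound 2 to compound 3 (0.11 log units; within the scatter), and chloro in place of hydrogen gives a 1.5-fold higher number from compound 1 to compound 3 (0.19 log units; within the scatter). At this position, then, chloro cannot be told apart from either bromo or hydrogen, so neither halogen has shifted the number beyond the scatter. No measurement is available that would explain this result. The compounds shown leave open whether a different kind of group on this carbon, such as an amine or a carboxylic acid, would move the number beyond the scatter.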